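Amine replacement on the chain carbon: notes toward compound 3

The source may report more compounds than this note shows. Statements on the series, on what has been measured and on what is new or still open speak of the compounds shown alone.

Among the measured compounds shown here, compound 1 `CCNC(=O)c1nnn(-c2cc(C(C)C)c(O)cc2O)c1-c1ccc(CN2CCCC(O)C2)cc1` gives 62 nM in a functional assay on NCI-H460 cells (Homo sapiens) for inhibition, read by sulforhodamine B assay, with a stated time of 72 h (a higher number here means a weaker inhibitor, a lower number a stronger inhibitor), the higher of the two numbers measured so far. Compound 2 `CCNC(=O)c1nnn(-c2cc(C(C)C)c(O)cc2O)c1-c1ccc(CNCC2CCCCC2)cc1` gives 2.1 nM in this assay. The change now considered in compound 3 `CCNC(=O)c1nnn(-c2cc(C(C)C)c(O)cc2O)c1-c1ccc(CNCCCN(CC)CC)cc1` is (3-(diethylamino)propyl)amino in place of 3-hydroxypiperidin-1-yl on a saturated chain carbon bound to an aromatic carbon. For the measured compounds named here, the one measured step, a 30-fold lower number from compound 1 to compound 2 (1.47 log units; beyond the scatter), also swapped the same ring for a group with no ring and was large. For compound 3 a lower number is therefore expected, though with less confidence since the entering group is not the one measured, so a smaller step of a 4.1-fold lower number from compound 1 to compound 3 (0.62 log units; beyond the scatter) is estimated. Compound 3 is expected near 15 nM, within 4 nM to 60 nM.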

Compound 3, half-maximal inhibitory concentration: 412 nM
For compound 3 the middle estimate is 27-fold (1.44 log units) below the measured one; measured number above the stated range.
By their numbers in this assay, from the lowest: compound 2; then compound 1; then compound 3.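

Losing the ring does not by itself lower the number in this assay: compound 3 gives a 6.6-fold higher number from compound 1 to compound 3 (0.82 log units; beyond the scatter) and so runs against the fall seen with compound 2. Among the open-chain amines, the outer group carries much weight, with 2-(diethylamino)ethyl in place of cyclohexyl giving a 200-fold higher number from compound 2 to compound 3 (2.29 log units; beyond the scatter). No available evidence bears on this result.

The compounds shown do not separate the diethylamino end from the chain carrying it. Going by these compounds, how a plain hexylamino group or a 4-methylpiperazin-1-yl ring would stand at this place remains open.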